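The source may hold more compounds than are shown below. What is called first, only, known or untested is meant among the compounds shown, and "the series" means these compounds.

Measured in an ADME assay on LLC-MK2 cells (Macaca mulatta) for cytotoxicity, read by spectrophotometry and crystal violet staining, with a stated time of 4 days; a lower number here means that less compound is tolerated, a higher number that more compound is tolerated:
compound 1 `CC(C)n1ncc2c(C(=O)Nc3cc(S(N)(=O)=O)ccc3F)cc(-c3cccs3)nc21`: 25000 nM
compound 2 `CC(C)n1ncc2c(C(=O)Nc3ccccn3)cc(-c3ccsc3)nc21`: 25000 nM
compound 3 `CC(C)n1ncc2c(C(=O)Nc3c(F)cc(F)cc3F)cc(-c3cccs3)nc21`: > 200000 nM, a limit of the assay and not a number

For compound 3 the read-out is only a limit, (the limit of > 200000 nM in this assay, at which 1 of the 3 values shown sits), so compound 3 stands at the edge of the tested range with no number attached. Compound 1 and compound 2 each carry a measured half-maximal cytotoxic concentration instead. Compound 4 `CC(C)n1ncc2c(C(=O)Nc3cccc(F)c3F)cc(-c3cccs3)nc21` differs from compound 3 in one place only, on the amide-type nitrogen: 2,3-difluorophenyl in place of 2,4,6-trifluorophenyl on an amide-type nitrogen. No measured step between two of the compounds shown covers this change, so the size of the step in this assay must be judged from the three values alone. Given that compound 1 at 25000 nM and compound 2 at 25000 nM sit inside the tested range while compound 3 runs past it, the step from compound 3 to compound 4 is expected to go toward less compound tolerated by an at least 2.0-fold lower number from compound 3 to compound 4 (0.30 log units; that floor lies within the scatter). That compound 4 might also run past the tested range cannot be excluded. Compound 4 is therefore estimated at 100000 nM in this assay, with a range of 25000 nM to 200000 nM.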

Compound 4, half-maximal cytotoxic concentration: 75000 nM
Compound 4: the middle estimate sits 1.3-fold (0.12 log units) above what was measured, within the range that was stated.
By their numbers in this assay, from the lowest: compounds 1 and 2 (each within the scatter of the next); then compound 4. At a limit, above all of these: compound 3.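

Among the compounds shown here, this is the first one-place step: on the amide-type nitrogen, 2,3-difluorophenyl in place of 2,4,6-trifluorophenyl gives an at least 2.6-fold lower number from compound 3 to compound 4 (0.42 log units; beyond the scatter) in this assay. The aryl group on this nitrogen can therefore move the read-out beyond the scatter with the rest of the molecule unchanged, and compound 4 gives 75000 nM, a measured number for a fluorinated phenyl at this place. The step is a floor only, its true size unread, as compound 3 carries a limit of the assay and not a number: the limit of > 200000 nM in this assay, at which 1 of the 4 values shown sits.

This single step cannot separate the loss of one fluorine from the change in where the fluorines sit. From the compounds shown here alone, how a plain phenyl, or a phenyl carrying a carboxylic acid or an amine, would stand on this nitrogen in this assay remains open.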